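Fluoro on the pyrimidine in a low-toxicity series

The source may report more compounds than this note shows. Statements on the series, on what has been measured and on what is new or still open speak of the compounds shown alone.

Measured compounds:
compound 1, `O=C1CC(c2ccccc2)CN1c1cnn2c1CN(C(=O)Nc1cc(F)c(F)c(F)c1)C(C1CC1)C2`: 12800 nM
compound 2, `O=C1CC(c2ncccn2)CN1c1cnn2c1CN(C(=O)Nc1cc(F)c(F)c(F)c1)C(C1CC1)C2`: > 200000 nM

Two compounds share one core and differ only in the group on a saturated ring carbon. In a toxicity assay on HepG2 2.2.15 cells (Homo sapiens) for cytotoxicity, read by CellTiter-Glo (on this read-out higher numbers stand for lower toxicity in this test and lower numbers for higher toxicity in this test), compound 1 gives 12800 nM. Compound 2 reaches the limit of this assay, giving > 200000 nM, a limit and not a number. The step of an at least 15-fold higher number from compound 1 to compound 2 (1.19 log units; beyond the scatter) therefore stands as a lower bound, since compound 2 sits at the limit of > 200000 nM in this assay, at which 1 of the 2 values shown sits.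

Compound 3, `O=C1CC(c2ncc(F)cn2)CN1c1cnn2c1CN(C(=O)Nc1cc(F)c(F)c(F)c1)C(C1CC1)C2`, has not yet been measured. It differs from compound 2 by fluoro in place of hydrogen on an aromatic carbon. Within the data shown here, no measured step changes the same position, so the only bearing comes from the pyrimidin-2-yl compound 2 itself, which already sits at the limit. With one fluorine on the aromatic ring, compound 3 is expected to stay near where compound 2 stands in this assay, so the step of a number no higher from compound 2 to compound 3 (the limit leaves the size open) is expected to lie within the scatter. Compound 3 is accordingly estimated at 200000 nM, with a range from 70000 nM to 400000 nM, and most likely again reported only as a limit.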

Compound 3, half-maximal cytotoxic concentration: 115000 nM
For compound 3 the middle estimate is 1.7-fold (0.24 log units) above the measured one; measured number inside the range.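

With the 5-fluoropyrimidin-2-yl group, this series gives a measured number for a pyrimidine-bearing compound in this assay, and the step of a 9.0-fold higher number from compound 1 to compound 3 (0.95 log units; beyond the scatter) puts a real size on the replacement of phenyl, showing that lower toxicity in this test relative to compound 1 holds with fluoro on the ring. For compound 2, the value of > 200000 nM is a limit and not a number: the limit of > 200000 nM in this assay, at which 1 of the 3 values shown sits.

The step of an at least 1.7-fold lower number from compound 2 to compound 3 (0.24 log units; that floor lies within the scatter) is therefore only a floor, so the effect of this change, para to a large group, may be negligible or larger, and its true size cannot be read from these values.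

The compounds shown leave open how other groups at the same aromatic carbon, such as chloro, methyl or an amine, would read in this assay. They also leave open whether fluoro on the phenyl of compound 1 would shift that compound's number at all, and so whether any fluoro effect depends on the pyrimidine ring.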